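Cytotoxicity tolerance in a chloroindole–cyclopropyl series

This account rests on a few compounds, and the source may have more. Where it says the series, first, only, none or still open, it means among the compounds named here.

Measured so far:
compound 1 `O=c1n(Cc2cc3cc(Cl)ccc3n2CCCCO)c2cnccc2n1C1CC1`: > 50000 nM
compound 2 `NC(=O)CCCn1c(Cn2c(=O)n(C3CC3)c3ccncc32)cc2cc(Cl)ccc21`: > 50000 nM

In an ADME assay on HeLa cells (Homo sapiens) for cytotoxicity, read by ATP content, with a stated time of 3 days (a lower number here means that less compound is tolerated, a higher number that more compound is tolerated), compound 1 shows only a limit, > 50000 nM. Compound 2 likewise reaches only a limit in this assay, > 50000 nM. The step that the two limits leave unreadable from compound 1 to compound 2 is therefore unreadable, since the limit of > 50000 nM in this assay, at which 2 of the 2 values shown sit, holds for both. Compound 3 `CC(C)(O)CCCn1c(Cn2c(=O)n(C3CC3)c3ccncc32)cc2cc(Cl)ccc21` carries 1-hydroxy-1-methylethyl in place of carbamoyl on a saturated chain carbon, three bonds along the chain from an aromatic nitrogen. Among the compounds with values here, no measured step bears on this change in this assay; the only comparison available sits at the limit. Compound 3 is expected to remain at that limit, with a step that the limit leaves unreadable from compound 2 to compound 3 as the estimated step. The estimate for compound 3 is 70000 nM, ranging from 30000 nM to 200000 nM.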

Compound 3, half-maximal cytotoxic concentration: > 50000 nM
Compound 3 was reported as a limit; the forecaster's own chance of this, stated with the estimate: 85%; the middle value lies beyond the limit too.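

No step can be read among compound 1, compound 2 and compound 3 in this assay, since all three stop at the same limit: the limit of > 50000 nM in this assay, at which 3 of the 3 values shown sit.

As far as these compounds go, whether the hydroxymethyl, carbamoyl and 1-hydroxy-1-methylethyl chain ends differ in tolerance remains open.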